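Fluorophenyl position change in a succinimide piperazine amide series

A few compounds are considered here, and "the series" means these few. Any claim that something is new, unique, unknown or untested is made for them only; others in the source may bear on it.

Values in a functional assay on the whole organism (strain Swiss) with Mus musculus as the target, in the maximal electroshock model, with a stated time of 0.5 h, at a dose of 100 mg/kg by the intraperitoneal route; a lower number here means a weaker effect, a higher number a stronger effect of the compound at the dose given:
compound 1 `COc1cccc(N2CCN(C(=O)C(C)N3C(=O)CCC3=O)CC2)c1`: 0%
compound 2 `CC(C(=O)N1CCN(c2ccccc2)CC1)N1C(=O)CCC1=O`: 0%
compound 3 `CCC(C(=O)N1CCN(c2cccc(F)c2)CC1)N1C(=O)CCC1=O`: 0%

Compound 3 stands level with compound 1 and compound 2 at the digits shown; none of the three reaches a measurable effect at this dose. Within the data shown here, the single one-place step so far, hydrogen in place of methoxy on an aromatic carbon, gave no change at the digits printed from compound 1 to compound 2 (within the scatter). Compound 4 `CCC(C(=O)N1CCN(c2ccccc2F)CC1)N1C(=O)CCC1=O` carries 2-fluorophenyl in place of 3-fluorophenyl on an amine nitrogen in a ring. Among the measured compounds shown here, no measured step moves a substituent within the aromatic ring, so the series offers no direct precedent; the only step available, no change at the digits printed from compound 1 to compound 2 (within the scatter), was flat. The expected step is therefore no change at the digits printed from compound 3 to compound 4 (within the scatter), none beyond the scatter. Compound 4 is estimated at 0% in this assay, with a range of 0% to 15%.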

Compound 4, a percentage reported as activity, at one dose (the size of the read-out at that dose, not a potency): 0%
Estimate against measurement, compound 4: no gap at the digits printed; measured number inside the range.
By their numbers in this assay, from the lowest: compounds 1, 2, 3 and 4 (each within the scatter of the next).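

In this assay, 2-fluorophenyl in place of 3-fluorophenyl on the amine nitrogen in the ring gave no change at the digits printed from compound 3 to compound 4 (within the scatter). Among these compounds, this is the first step that moves a substituent within the aromatic ring, and the fluorine's place on that ring leaves the read-out without any measurable effect at this dose. No supporting evidence bears on this flat result.

Since every compound shown lacks a measurable effect, the read-out cannot rank these fluorine positions. As far as these compounds go, whether trifluoromethyl in place of fluorine, or a longer chain on the shared core, would give a measurable effect remains open.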